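Moving the Sulfonamide to a Neighbouring Ring Position

This account rests on a few compounds, and the source may have more. Where it says the series, first, only, none or still open, it means among the compounds named here.

Compound 1 `COC(=O)C(c1ccccc1)n1nnnc1[C@@H](COCc1ccccc1)NC(=O)C(C)(C)N` gives 470 nM in an assay on isolated protein for displacement of a labelled ligand from growth hormone secretagogue receptor type 1 (Homo sapiens), with a stated time of 1 h; on this read-out lower numbers stand for stronger inhibition and higher numbers for weaker inhibition. Compound 2 `CC(C)(N)C(=O)N[C@H](COCc1ccccc1)c1nnn(Cc2ccccc2)n1`, which carries a plain benzyl group on the same core, gives 4750 nM in this assay. Within the data shown here, compound 3 `CC(C)(N)C(=O)N[C@H](COCc1ccccc1)c1nnn(Cc2ccc(NS(C)(=O)=O)cc2)n1` reaches only a limit of the assay, > 5000 nM in this assay, so its true number is not known and it stands at the weak end of the three compounds measured so far. Among the measured compounds shown here, the one measured step that bears on the new compound is an at least 1.0-fold higher number from compound 2 to compound 3 (0.02 log units; that floor lies within the scatter), a floor that sits within the scatter; it is uncertain because of the limit of > 5000 nM in this assay, at which 1 of the 3 values shown sits.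

Compound 4 `CC(C)(N)C(=O)N[C@H](COCc1ccccc1)c1nnn(Cc2cccc(NS(C)(=O)=O)c2)n1` differs from compound 3 by 3-(methanesulfonamido)phenyl in place of 4-(methanesulfonamido)phenyl on a saturated chain carbon bound to an aromatic nitrogen. No measured step tests a move of this group from one ring position to another, so the size of the change cannot be read from the numbers shown. What the data do show is that compound 2 and compound 3 both sit near the weak end, and compound 4 keeps every atom of compound 3.

For compound 4 the expected step is a step that the limit leaves unreadable from compound 3 to compound 4, which means no change that can be told apart from the scatter. Compound 4 is therefore expected to give about 6000 nM in this assay, within a range from 2000 nM to 20000 nM, with a real chance that only a limit is reported again.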

Compound 4, inhibition constant: > 5000 nM
Compound 4 was reported as a limit; the forecaster's own chance of this, stated with the estimate: 60%; the middle value lies beyond the limit too.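

Compound 4 shows that the second placement behaves like the first: with 3-(methanesulfonamido)phenyl, as with 4-(methanesulfonamido)phenyl, this assay gives only a limit and not a number. Against the plain benzyl group of compound 2, the only readable record is an at least 1.0-fold higher number from compound 2 to compound 4 (0.02 log units; that floor lies within the scatter), so neither placement of methanesulfonamido has produced a number that can be told apart from compound 2. The steps between the two limits cannot be read, and the move itself therefore has no measurable size: the limit of > 5000 nM in this assay, at which 2 of the 4 values shown sit.

As far as these compounds go, how far compound 3 and compound 4 lie beyond the limit remains unknown, so a real difference between the two placements could be hidden there. From the compounds shown here alone, it also remains open whether a different group at either place on the phenyl ring of the benzyl group, such as an amine or a carboxylic acid, would give a value that can be read in this assay.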